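The source may hold more compounds than are shown below. What is called first, only, known or untested is meant among the compounds shown, and "the series" means these compounds.

Working notes on the series. For the measured compounds named here, compound 1 `CSc1ccc(CNc2nc(SC)nc3ncccc23)cc1` carries the only number recorded in an ADME assay on BEAS-2B cells (Homo sapiens) for cytotoxicity, read by MTT assay, with a stated time of 72 h; a lower number here means a stronger inhibitor of growth, a higher number a weaker inhibitor of growth; in this assay compound 1 gives 3770 nM. Compound 2 `[SeH]c1nc([SeH])c2ccccc2n1` has no result in this assay, recorded as "not determined" (no result reported), so it offers no comparison. Compound 3 `CSc1nc(NCc2ccccc2)c2cccnc2n1` differs from compound 1 by hydrogen in place of methylsulfanyl on an aromatic carbon. Going by the values given here, no measured pair shows such a step, so the expected step from compound 1 to compound 3 in this assay is a 1.2-fold higher number from compound 1 to compound 3 (0.08 log units; within the scatter), taken as small and not beyond the usual scatter. On that basis compound 3 is estimated at 4500 nM, with a range from 1800 nM to 11000 nM.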

Compound 3, concentration for total growth inhibition: 61700 nM
Compound 3: the middle estimate sits 14-fold (1.14 log units) below what was measured; measured number above the stated range.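

In this assay, the aromatic carbon para to a large group proves sensitive to substitution: hydrogen in place of methylsulfanyl gives a 16-fold higher number from compound 1 to compound 3 (1.21 log units; beyond the scatter), making compound 3 the weaker inhibitor of growth. This single pair gives the first measured size for a change at this position, on the core of compound 1. Nothing available explains the step. Whether methylsulfanyl itself matters or another group would serve equally remains open, as the compounds shown include no methoxy, chlorine or amine at this place. Whether the step carries over to other cores is also unresolved.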